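A few compounds are considered here, and "the series" means these few. Any claim that something is new, unique, unknown or untested is made for them only; others in the source may bear on it.

Working notes on the series. For the measured compounds named here, compound 3 `COc1cc2c(Oc3ccc(NC(=O)c4cc(-c5ccccc5C)ccn4)cc3F)ccnc2cc1OCCCN1CCCC1` stands highest of the three numbers so far in a functional assay on HT-29 cells (Homo sapiens) for cytotoxicity, read by MTT assay, with a stated time of 72 h; on this read-out lower numbers stand for stronger inhibition and higher numbers for weaker inhibition: compound 3 gives 1150 nM, whereas compound 2 `COc1cc2c(Oc3ccc(NC(=O)c4cc(-c5ccc(C)cc5)ccn4)cc3F)ccnc2cc1OCCCN1CCCC1` gives 350 nM and compound 1 `COc1cc2c(Oc3ccc(NC(=O)c4cc(-c5ccccc5F)ccn4)cc3F)ccnc2cc1OCCCN1CCCCC1` gives 320 nM. Going by the values given here, the only single-point step measured is a 3.3-fold higher number from compound 2 to compound 3 (0.52 log units; beyond the scatter), which shows the 2-methylphenyl group carrying a clear penalty against the 4-methylphenyl group on the shared core.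

Compound 4 `COc1cc2c(Oc3ccc(NC(=O)c4cc(-c5ccccc5F)ccn4)cc3F)ccnc2cc1OCCCN1CCCC1` is reached from compound 3 by fluoro in place of methyl on an aromatic carbon; the same difference, cut one bond further out, reads 2-methylphenyl to 2-fluorophenyl. Among the compounds with values here, no measured step covers this exact exchange. Compound 1 carries the same 2-fluorophenyl group but a different amine on the side chain, so its value of 320 nM bears on the question only loosely; it does show that a 2-fluorophenyl compound in this set can sit well under the number for compound 3. On that basis a lower number is expected for compound 4, in the order of a 2.6-fold lower number from compound 3 to compound 4 (0.41 log units; beyond the scatter), though the uncertainty is wide. Compound 4 is estimated at 450 nM, with a range of 200 nM to 1100 nM.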

Compound 4, half-maximal inhibitory concentration: 230 nM
Compound 4: middle estimate off by 2.0-fold (0.29 log units), on the high side; the range from low to high includes it.
By their numbers in this assay, from the lowest: compounds 4, 1 and 2 (each within the scatter of the next); then compound 3.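

In this assay the exchange on an aromatic carbon ortho to a large group now has a direct measure in a 5.0-fold lower number from compound 3 to compound 4 (0.70 log units; beyond the scatter) and so the penalty seen for 2-methylphenyl is not shared by 2-fluorophenyl at this place. The other two steps stay within the scatter: a 1.5-fold lower number from compound 2 to compound 4 (0.18 log units; within the scatter) leaves 2-fluorophenyl and 4-methylphenyl unseparated, and a 1.4-fold lower number from compound 1 to compound 4 (0.14 log units; within the scatter) leaves pyrrolidin-1-yl and piperidin-1-yl unseparated on the 2-fluorophenyl compounds. Nothing available explains the gap between the methyl and fluoro compounds.

Open, as far as these compounds go, is whether chloro or methoxy at this place would read like fluoro or like methyl. Also open, from the compounds shown here alone, is whether a morpholine on the side chain would hold the number seen with the two saturated amines.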